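The source may report more compounds than this note shows. Statements on the series, on what has been measured and on what is new or still open speak of the compounds shown alone.

Three compounds have been measured in an ADME assay on BHK-21 cells (Mesocricetus auratus) for cytotoxicity, read by MTT assay, with a stated time of 72 h; on this read-out higher numbers stand for lower toxicity in this test and lower numbers for higher toxicity in this test:

Compound 1 `NS(=O)(=O)c1ccc(N2N=C(c3ccc(Oc4ccccc4)cc3)CC2c2ccc(Cl)cc2)cc1` gives 7000 nM.
Compound 2 `NS(=O)(=O)c1ccc(N2N=C(c3ccc(OCc4ccccc4)cc3)CC2c2ccccc2F)cc1` gives 90000 nM.
Compound 3 `Cc1cccc(C2CC(c3ccccc3)=NN2c2ccc(S(N)(=O)=O)cc2)c1` gives 25000 nM.

Compound 1 gives the lowest of these three numbers, so it is the most toxic of the three in this assay; compound 3 sits beyond the usual scatter above it, and compound 2 lies further above still. Compound 4 `Cc1ccccc1C1CC(c2ccc(Oc3ccccc3)cc2)=NN1c1ccc(S(N)(=O)=O)cc1` has not yet been measured. It differs from compound 1 in one place: 2-methylphenyl in place of 4-chlorophenyl on a saturated ring carbon. Within the data shown here, no pair of measured compounds isolates this change, so the expectation rests only on the spread of the three values. The step is expected to be small and towards a higher number, estimated at a 1.7-fold higher number from compound 1 to compound 4 (0.23 log units; within the scatter). Compound 4 is therefore estimated to give 12000 nM in this assay, expected to fall between 4000 nM and 40000 nM.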

Compound 4, half-maximal cytotoxic concentration: 7000 nM
Beside the measured number, compound 4's estimate is 1.7-fold (0.23 log units) above it; the range from low to high includes it.
By their numbers in this assay, from the lowest: compounds 1 and 4 (each within the scatter of the next); then compound 3; then compound 2.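

In this assay, among these compounds, putting 2-methylphenyl in place of 4-chlorophenyl on the saturated ring carbon gives no change at the digits printed from compound 1 to compound 4 (within the scatter) and is the first direct look at this position. With the rest of compound 1 held fixed, these two groups are interchangeable in this test. Nothing at hand accounts for this result.

From the compounds shown here alone, it remains open whether a more different group at this position, such as an amine or a carboxylic acid, would move the number. It is also unknown whether these two groups would stay interchangeable on another core.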